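The source may report more compounds than this note shows. Statements on the series, on what has been measured and on what is new or still open speak of the compounds shown alone.

Measured in a functional assay on MCF7 cells (Homo sapiens) for inhibition, read by sulforhodamine B assay, with a stated time of 48 h; a lower number here means a stronger inhibitor of growth, a higher number a weaker inhibitor of growth:
- compound 1 `c1ccc(-c2ccc(NC3=NCCO3)cc2)cc1`: 10600 nM
- compound 2 `O=C(CCl)NC(=O)Nc1ccc(C2CCCCC2)cc1`: 1500 nM
- compound 3 `O=C(CCl)NC(=O)Nc1ccc(-c2ccccc2)cc1`: 3900 nM

Compound 3 holds the middle place of these three numbers, with compound 2 lower and compound 1 higher. The next compound, compound 4 `O=C(CCl)NC(=O)Nc1ccc(OC2CCCC2)cc1`, keeps everything in compound 3 except one group, with cyclopentyloxy in place of phenyl on an aromatic carbon.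

Going by the values given here, one measured step bears on this change. Phenyl in place of cyclohexyl gave a 2.6-fold higher number from compound 2 to compound 3 (0.41 log units; beyond the scatter), a modest rise beyond the scatter. Compound 4 likewise gives up the phenyl for a non-aromatic ring, so a modest move to a lower number in this assay is expected. Among the compounds with values here, the guide is imperfect, since no measured compound carries cyclopentyloxy and the ring in compound 4 is five-membered, so the expected step may not clear the scatter.

The estimate amounts to a 1.6-fold lower number from compound 3 to compound 4 (0.19 log units; within the scatter), an expected change of modest size. For compound 4 the estimated value is 2500 nM, with an expected range from 1100 nM to 5500 nM.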

Compound 4, concentration for 50% growth inhibition: 3900 nM
The estimate for compound 4 lay 1.6-fold (0.19 log units) below the measured number, within the range that was stated.
By their numbers in this assay, from the lowest: compound 2; then compounds 3 and 4 (each within the scatter of the next); then compound 1.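

In this assay, cyclopentyloxy in place of phenyl gives no change at the digits printed from compound 3 to compound 4 (within the scatter), so at this position a non-aromatic ring does not by itself lower the number. Cyclopentyloxy in place of cyclohexyl gives a 2.6-fold higher number from compound 2 to compound 4 (0.41 log units; beyond the scatter), which leaves compound 2, with its cyclohexyl group, with the lowest number among the three compounds that share this core. Nothing available offers an explanation for these results.

Compound 4 differs from compound 2 both in ring size and in the oxygen that joins the ring to the core, and the compounds shown do not separate these two changes. As far as these compounds go, how an amine or a carboxylic acid at this position would read also remains open.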